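The source may report more compounds than this note shows. Statements on the series, on what has been measured and on what is new or still open speak of the compounds shown alone.

In an ADME assay on HepG2 cells (Homo sapiens) for cytotoxicity, read by MTT assay, with a stated time of 48 h, tested at 1 uM (on this read-out higher numbers stand for a stronger effect at the one concentration tested and lower numbers for a weaker effect), the three measured compounds give the following numbers:

Compound 1 `O=c1cc(-c2ccccc2)oc2cc(OCCCCCCCCN3CCCC3)ccc12` gives 11.3%.
Compound 2 `O=c1cc(-c2ccccc2O)oc2cc(OCCCCCCCCN3CCCC3)ccc12` gives 5.92%.
Compound 3 `COc1ccccc1-c1cc(=O)c2ccc(OCCCCCCCCN3CCCC3)cc2o1` gives 5.9%.

Compound 3 stands alongside the other two: the step of a number 0 percentage points lower from compound 2 to compound 3 (within the scatter) and the step of a number 5.4 percentage points lower from compound 1 to compound 3 (within the scatter) are both within the scatter, so on these numbers the three compounds cannot be told apart in this assay.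

Compound 4 `O=c1cc(-c2ccccc2OCc2ccccc2)oc2cc(OCCCCCCCCN3CCCC3)ccc12` differs from compound 3 in one place: phenyl in place of hydrogen on a saturated chain carbon bound to an oxygen on an aromatic ring. Among the compounds with values here, two measured steps bear on this position. The step of a number 0 percentage points lower from compound 2 to compound 3 (within the scatter) puts a methyl on the same oxygen without moving the number beyond the scatter, and the step of a number 5.4 percentage points lower from compound 1 to compound 3 (within the scatter), which installs the methoxy group itself, also stays within the scatter. Within the data shown here, the phenyl that enters in compound 4 is larger than anything varied at this position so far, and nothing in the measured set shows a change at this oxygen that is read as a move beyond the scatter. The expected step in this assay is therefore a number 1.1 percentage points higher from compound 3 to compound 4 (within the scatter), no more than the scatter allows in either direction. Compound 4 is thus estimated at 7%, with a range from 0% to 17%.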

Compound 4, a percentage reported as inhibition, at one concentration (the size of the read-out at that concentration, not a potency): 19.7%
For compound 4 the middle estimate is 12.7 percentage points below the measured one; measured number above the stated range.
By their numbers in this assay, from the lowest: compounds 3, 2, 1 and 4 (each within the scatter of the next, the first and the last beyond it).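

In this assay this oxygen no longer looks indifferent to what it carries: methyl on the oxygen left the number within the scatter, whereas benzyl on the same oxygen gives a number 13.8 percentage points higher from compound 2 to compound 4 (beyond the scatter) and phenyl on the saturated chain carbon of the methoxy group gives a number 13.8 percentage points higher from compound 3 to compound 4 (beyond the scatter) in the same comparison. The change therefore separates compound 4 from the hydroxy and methoxy compounds, but against the compound with hydrogen on the aromatic carbon the benzyloxy group gives a number 8.4 percentage points higher from compound 1 to compound 4 (within the scatter) and so cannot be told apart from it, which limits the finding to the two substituted oxygens. Nothing available gives a reason for the difference between methoxy and benzyloxy.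

Compound 4 alone cannot show whether the phenyl ring itself or simply a larger group on this oxygen accounts for the step, and a cyclohexylmethyl group or a longer chain such as butyl in place of benzyl would address that question. Because the read-out comes from one concentration, it also leaves open how the compounds would compare across a range of concentrations.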